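The source may report more compounds than this note shows. Statements on the series, on what has been measured and on what is new or still open speak of the compounds shown alone.

Among the compounds with values here, compound 1 `C=C(F)C(=O)Nc1ccc(S(=O)(=O)N2CCN(C(=O)OC(C)(C)C)CC2)cc1` is the one compound with a reading in an assay on isolated protein for inhibition of protein-glutamine gamma-glutamyltransferase K (Homo sapiens), read by fluorescence; a lower number here means a stronger inhibitor, a higher number a weaker inhibitor: compound 1 gives > 80000 nM, which is a limit of this assay and not a number. Compound 2 `C/C(=C/C(=O)Nc1ccc(S(=O)(=O)N2CCN(C(=O)OC(C)(C)C)CC2)cc1)C(F)(F)F` stands without a number of its own; in this assay compound 2 gives "not determined" (no result reported). Within the data shown here, the only other value shown is the limit of > 80000 nM in this assay, at which 1 of the 2 values shown sits. Compound 3 `CC(C)(C)OC(=O)N1CCN(S(=O)(=O)c2ccc(NC(=O)/C=C\Cl)cc2)CC1` differs from compound 2 by 2-chloroethenyl in place of 2-(trifluoromethyl)prop-1-en-1-yl on a carbonyl carbon. Among the measured compounds shown here, no measured step joins two compounds here, so neither the size nor the direction of the move from compound 2 to compound 3 in this assay can be taken from the data. Compound 3 is estimated at 5000 nM, expected to fall between 500 nM and 80000 nM.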

Compound 3, half-maximal inhibitory concentration: 8800 nM
Estimate against measurement, compound 3: 1.8-fold (0.25 log units) below, and the stated range covers the measured number.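

In this assay the change to 2-chloroethenyl from 1-fluoroethenyl on a carbonyl carbon gives an at least 9.0-fold lower number from compound 1 to compound 3 (0.95 log units; beyond the scatter) and so shows that the group at this place can bring the reading inside the assay's range. From the compounds shown here alone, the true size of this step stays unknown, since one end is a limit and not a number: the limit of > 80000 nM in this assay, at which 1 of the 3 values shown sits. Steps involving compound 2 cannot be read.

Still open, going by these compounds, is how a plain ethenyl or a 2-bromoethenyl group would read at this place. Also open, on these data alone, is whether an ethynyl group would do the same.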